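The compounds below may be only part of what the source reports. "The series", "measured", "known", "first", "only" and "open" are said of these compounds alone.

Compound 1 `CC[C@H](C)[C@H](N)CN(C(=O)[C@@H]1C[C@H]1c1ccccn1)c1ccc(-c2ccccc2)cc1`: 130 nM
Compound 2 `CC[C@H](C)[C@H](N)CN(C(=O)[C@@H]1C[C@H]1c1csc(C)n1)c1ccc(-c2ccccc2)cc1`: 1500 nM
Compound 3 `CC(C)C[C@H](N)CN(C(=O)[C@@H]1C[C@H]1c1ccccc1)c1ccc(C2=CCCC2)cc1`: 1200 nM

In a functional assay for agonist activity at G protein-coupled receptor 88 (Homo sapiens), read by HTRF and cAMP accumulation (a higher number here means that more compound is needed for the effect, a lower number that less compound is needed), compound 3 gives 1200 nM, the second highest of the three numbers; compound 2 sits within the scatter of it, whereas compound 1 gives 130 nM and lies well below. Compound 4 `CC(C)C[C@H](N)CN(C(=O)[C@@H]1C[C@H]1c1ccccc1)c1ccc(-c2ccc(Cl)cc2)cc1` differs from compound 3 in one place: 4-chlorophenyl in place of cyclopent-1-en-1-yl on an aromatic carbon. Among the compounds with values here, the one measured step, a 12-fold higher number from compound 1 to compound 2 (1.06 log units; beyond the scatter), concerns a different part of the molecule and does not bear on this change; compounds 1 and 3 differ in several places at once, so their two values alone say nothing about this position. No shown step therefore points to a size or a direction. Compound 4 is expected to give about 700 nM, with a range of 200 nM to 2500 nM. The expected step of a 1.7-fold lower number from compound 3 to compound 4 (0.23 log units; within the scatter) is estimated to stay within the scatter.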

Compound 4, half-maximal effective concentration: 640 nM
Compound 4: the middle estimate sits 1.1-fold (0.04 log units) above what was measured; measured number inside the range.
By their numbers in this assay, from the lowest: compound 1; then compounds 4, 3 and 2 (each within the scatter of the next, the first and the last beyond it).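

At this aromatic carbon, para to a large group, 4-chlorophenyl in place of cyclopent-1-en-1-yl gives (a 1.9-fold lower number from compound 3 to compound 4 (0.27 log units; within the scatter)) in this assay, the first step shown at this position. The position therefore accepts a six-membered aromatic ring of carbon as well as a five-membered non-aromatic one, with no change beyond the scatter. Nothing available explains this result. From the compounds shown here alone, whether the chlorine contributes remains open, as does how a plain phenyl, a methoxy group or an amine on that ring would read here.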